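A few compounds are considered here, and "the series" means these few. Any claim that something is new, unique, unknown or untested is made for them only; others in the source may bear on it.

Of the compounds shown here, three built on one shared core have been tested in a functional assay on MCF7 cells (Homo sapiens) for inhibition, read by CCK-8 assay; on this read-out higher numbers stand for weaker inhibition and lower numbers for stronger inhibition. Compound 1 `Oc1ccccc1/C=N/c1nnc(SCc2nnc(-c3ccccc3)o2)s1` gives 9760 nM, compound 2 `Oc1ccccc1/C=N/c1nnc(SCc2nnc(-c3ccc(F)cc3)o2)s1` gives 15600 nM, and compound 3 `COc1ccc(-c2nnc(CSc3nnc(/N=C/c4ccccc4O)s3)o2)cc1` gives 4560 nM. Compound 2 thus holds the highest of the three numbers, with a 1.6-fold higher number from compound 1 to compound 2 (0.20 log units; within the scatter) and a 3.4-fold lower number from compound 2 to compound 3 (0.53 log units; beyond the scatter). Compound 4 `O=[N+]([O-])c1ccc(-c2nnc(CSc3nnc(/N=C/c4ccccc4O)s3)o2)cc1` differs from compound 2 by nitro in place of fluoro on an aromatic carbon. Among the compounds with values here, no measured step puts nitro in place of fluoro. Within the data shown here, the one step that removes fluoro at this spot, a 3.4-fold lower number from compound 2 to compound 3 (0.53 log units; beyond the scatter), brought in methoxy, and a 2.1-fold lower number from compound 1 to compound 3 (0.33 log units; beyond the scatter) was of similar size, so neither tells what nitro does. Compound 4 is therefore estimated at 10000 nM, between 3500 nM and 30000 nM. The step this implies, a 1.6-fold lower number from compound 2 to compound 4 (0.19 log units; within the scatter), is expected to be modest at most, in an uncertain direction.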

Compound 4, half-maximal inhibitory concentration: 4250 nM
Beside the measured number, compound 4's estimate is 2.4-fold (0.37 log units) above it; the range from low to high includes it.
By their numbers in this assay, from the lowest: compounds 4 and 3 (each within the scatter of the next); then compounds 1 and 2 (each within the scatter of the next).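

Nitro at this spot gives stronger inhibition than fluoro (a 3.7-fold lower number from compound 2 to compound 4 (0.56 log units; beyond the scatter)) and than hydrogen (a 2.3-fold lower number from compound 1 to compound 4 (0.36 log units; beyond the scatter)), so a second group now joins methoxy in clearing the scatter against hydrogen, while fluoro does not. Nitro and methoxy cannot be told apart (a 1.1-fold lower number from compound 3 to compound 4 (0.03 log units; within the scatter)). No measurement at hand explains why these two groups land at the same level. From the compounds shown here alone, whether an amine or a carboxylic acid at this spot would match them stays open. So does whether nitro would act the same elsewhere on this ring.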